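The source may hold more compounds than are shown below. What is called first, only, known or untested is meant among the compounds shown, and "the series" means these compounds.

Measured so far in a functional assay (aorta) with Rattus norvegicus as the target; a lower number here means a stronger inhibitor, a higher number a weaker inhibitor:

compound 1 `CCO/C(O)=C1\C(COCCNc2nc(N)n(C)n2)=NC(C)=C(C(=O)OC)C1c1cccc(Cl)c1Cl` gives 3.98 nM
compound 2 `CCO/C(O)=C1\C(COCCNC2=NC(=O)C(C)(C)N2)=NC(C)=C(C(=O)OC)C1c1cccc(Cl)c1Cl` gives 20 nM
compound 3 `CCO/C(O)=C1\C(COCCNc2cc(Cl)ncn2)=NC(C)=C(C(=O)OC)C1c1cccc(Cl)c1Cl` gives 12.6 nM

The three compounds share one core and differ only in the ring attached to the amine nitrogen at the end of the side chain. Among them compound 1 has the lowest number, so it is the strongest inhibitor here: the nearest is compound 3, the furthest compound 2, and both gaps lie beyond the scatter.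

Compound 4 `CCO/C(O)=C1\C(COCCNc2nccnc2NC)=NC(C)=C(C(=O)OC)C1c1cccc(Cl)c1Cl` is the next step from compound 1. The change is 3-(methylamino)pyrazin-2-yl in place of 5-amino-1-methyl-1H-1,2,4-triazol-3-yl on an amine nitrogen.

Among the compounds with values here, two measured steps bear on this. Exchanging the triazole of compound 1 for a five-membered non-aromatic ring gave a 5.0-fold higher number from compound 1 to compound 2 (0.70 log units; beyond the scatter), and exchanging it for a six-membered aromatic ring gave a 3.2-fold higher number from compound 1 to compound 3 (0.50 log units; beyond the scatter). Between those two alternatives the difference was only a 1.6-fold lower number from compound 2 to compound 3 (0.20 log units; within the scatter). In both measured cases, leaving the triazole made the number go up by a modest amount. The pyrazine entering in compound 4 is, like the pyrimidine of compound 3, a six-membered aromatic ring, so a similar modest rise is expected, in the direction of weaker inhibition.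

For compound 4 the expected step is a 2.5-fold higher number from compound 1 to compound 4 (0.40 log units; beyond the scatter). Compound 4 is therefore estimated at 10 nM in this assay, with a range from 4 nM to 25 nM.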

Compound 4, half-maximal inhibitory concentration: 5.01 nM
For compound 4 the middle estimate is 2.0-fold (0.30 log units) above the measured one; the range from low to high includes it.
By their numbers in this assay, from the lowest: compounds 1 and 4 (each within the scatter of the next); then compounds 3 and 2 (each within the scatter of the next).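

Leaving the triazole does not by itself cost activity: in this assay, 3-(methylamino)pyrazin-2-yl on this amine nitrogen gives a 1.3-fold higher number from compound 1 to compound 4 (0.10 log units; within the scatter), so a six-membered aromatic ring can take the place of the five-membered one with no change that stands out from the scatter. Ring size alone does not set the number, since 6-chloropyrimidin-4-yl is also a six-membered aromatic ring with 2 hetero atoms, yet replacing it with 3-(methylamino)pyrazin-2-yl gives a 2.5-fold lower number from compound 3 to compound 4 (0.40 log units; beyond the scatter). The same pyrazine group also gives a 4.0-fold lower number from compound 2 to compound 4 (0.60 log units; beyond the scatter) when it replaces the five-membered non-aromatic ring, and among these four compounds the two whose rings carry an amino or methylamino group, compound 1 and compound 4, have the two lowest numbers.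

The compounds shown do not separate the methylamino group from the pyrazine ring that carries it, so a pyrazine with a plain amine, a chlorine or a methoxy group in that place would be the informative comparison. Nothing available here explains why these groups differ in this assay.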